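The compounds below may be only part of what the source reports. "The series", "measured", "known", "first", "only" and "open" are said of these compounds alone.

In a functional assay on PC-3 cells (Homo sapiens) for inhibition, read by MTT assay, with a stated time of 48 h (a lower number here means a stronger inhibitor, a higher number a weaker inhibitor), compound 1 `COc1ccc(CN(c2cc(OC)c(OC)c(OC)c2)S(=O)(=O)c2ccc(C)cc2)cc1` gives 8220 nM. Compound 2 `COc1ccc(CN(c2cc(OC)c(OC)c(OC)c2)S(=O)(=O)c2ccc(C(C)(C)C)cc2)cc1` carries tert-butyl in place of methyl on an aromatic carbon, and in this assay compound 2 gives 28600 nM, a step of a 3.5-fold higher number from compound 1 to compound 2 (0.54 log units; beyond the scatter). Compound 3 `COc1cc(N(Cc2nc3ccccc3[nH]2)C(=O)c2ccc(C)cc2)cc(OC)c1OC` rests on another core; the difference between the two cores is not broken down here. In this assay compound 3 gives 42000 nM, a number within the scatter of compound 2 and beyond the scatter of compound 1. Compound 4 `COc1cc(N(Cc2nc3ccccc3[nH]2)C(=O)c2ccc(C(C)(C)C)cc2)cc(OC)c1OC` is the unmeasured partner of compound 3 and carries tert-butyl in place of methyl on an aromatic carbon, the same change as seen between compound 1 and compound 2, at the same kind of place. In this assay the expected step is a 2.4-fold higher number from compound 3 to compound 4 (0.38 log units; beyond the scatter), resting on the earlier step of a 3.5-fold higher number from compound 1 to compound 2 (0.54 log units; beyond the scatter). Compound 4 is therefore estimated at 100000 nM, within 35000 nM to 300000 nM, with a fair chance that only a limit is returned.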

Compound 4, half-maximal inhibitory concentration: 46000 nM
Compound 4: middle estimate off by 2.2-fold (0.34 log units), on the high side; the range from low to high includes it.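

Replacing 4-methylphenyl with 4-(tert-butyl)phenyl on the core of compound 3 gives a 1.1-fold higher number from compound 3 to compound 4 (0.04 log units; within the scatter) in this assay, so the size of the step seen on the core of compound 1 does not carry over. The two steps differ when set side by side: the same change on two cores in this assay, a 3.5-fold higher number (0.54 log units; beyond the scatter) from compound 1 to compound 2 and a 1.1-fold higher number (0.04 log units; within the scatter) from compound 3 to compound 4, 3.2-fold (0.50 log units) apart, beyond the scatter of two such steps. In this series, the step on one core is therefore a poor guide to the step on the other, but these two pairs do not show which difference between the cores matters or how other cores would respond.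

Still open, going by these compounds, is how an ethyl group, intermediate in size between methyl and tert-butyl, would behave at this place on each core. On these data alone, an amine or a carboxylic acid at the same place is equally open.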